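The source may report more compounds than this note shows. Statements on the series, on what has been measured and on what is new or still open speak of the compounds shown alone.

Three compounds share one core and differ in the group on an amide-type nitrogen: compound 1 (`O=C(CCCCCCNC(=O)C(O)(O)C(F)(F)F)Nc1ccccc1Br`), compound 2 (`O=C(CCCCCCNC(=O)C(O)(O)C(F)(F)F)Nc1ccc(Br)cc1`) and compound 3 (`CC(=O)c1ccc(NC(=O)CCCCCCNC(=O)C(O)(O)C(F)(F)F)cc1`). In a functional assay on HCT-116 cells (Homo sapiens) for inhibition, read by colorimetric assay, with a stated time of 3 days (on this read-out higher numbers stand for weaker inhibition and lower numbers for stronger inhibition), compound 1 gives 14500 nM, compound 2 gives 3130 nM and compound 3 gives 12100 nM. The steps to compound 3 are a 1.2-fold lower number from compound 1 to compound 3 (0.08 log units; within the scatter) and a 3.9-fold higher number from compound 2 to compound 3 (0.59 log units; beyond the scatter), which places it level with the 2-bromophenyl member and on the weaker side of the 4-bromophenyl member.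

Compound 4 (`O=C(CCCCCCNC(=O)C(O)(O)C(F)(F)F)Nc1nccs1`) carries 1,3-thiazol-2-yl in place of 4-acetylphenyl on an amide-type nitrogen. Going by the values given here, no measured step replaces the six-membered aromatic ring of carbon only, so the guides are the changes among the three measured groups. The largest of these is a 4.6-fold lower number from compound 1 to compound 2 (0.67 log units; beyond the scatter), and it is modest. A step no larger than that is therefore expected in this assay, with no firm direction and quite possibly none beyond the scatter. The expected change is a 1.3-fold lower number from compound 3 to compound 4 (0.13 log units; within the scatter). For compound 4 the estimated value is 9000 nM, with an expected range from 3000 nM to 25000 nM.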

Compound 4, half-maximal inhibitory concentration: 10800 nM
Beside the measured number, compound 4's estimate is 1.2-fold (0.08 log units) below it; the range from low to high includes it.
By their numbers in this assay, from the lowest: compound 2; then compounds 4, 3 and 1 (each within the scatter of the next).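

In this assay, compound 4 stands level with the other two weaker members: the step is a 1.1-fold lower number from compound 3 to compound 4 (0.05 log units; within the scatter) and, against the 2-bromophenyl member, a 1.3-fold lower number from compound 1 to compound 4 (0.13 log units; within the scatter). At this amide-type nitrogen, then, a 1,3-thiazol-2-yl of 5 heavy atoms, with a five-membered aromatic ring with 2 hetero atoms, reads the same as groups built on a six-membered aromatic ring of carbon only, while compound 2 remains apart, with a 3.5-fold higher number from compound 2 to compound 4 (0.54 log units; beyond the scatter); among these four, only the 4-bromophenyl group is set off from the rest. Nothing available bears on the reason for this pattern.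

The compounds shown leave open whether a 4-chlorophenyl or 4-methoxyphenyl group would side with compound 2 or with the other three. They also leave open whether a bromo group on the 1,3-thiazol-2-yl ring would shift compound 4 at all.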